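The source may report more compounds than this note shows. Statements on the series, on what has been measured and on what is new or still open speak of the compounds shown alone.

compound 1 `CC#CCn1c(N2CCC[C@@H](N)C2)cc(=O)n(Cc2cc(F)cc(F)c2)c1=O`: 2.12
compound 2 `CC#CCn1c(N2CCC[C@@H](N)C2)cc(=O)n(CCC)c1=O`: 0.9

In a physicochemical assay for lipophilicity (on this read-out higher numbers stand for higher lipophilicity and lower numbers for lower lipophilicity), compound 2 has the lower of the two numbers, and its gap to compound 1 lies beyond the scatter. Compound 3 `CC#CCn1c(N2CCC[C@@H](N)C2)cc(=O)n(CCCCCCCCCC)c1=O` has not yet been measured. It differs from compound 2 at one place: heptyl in place of hydrogen on a saturated chain carbon, three bonds along the chain from an aromatic nitrogen, on a saturated chain carbon, three bonds along the chain from an aromatic nitrogen.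

Among the compounds with values here, only one measured step bears on this change: a number 1.22 log units lower from compound 1 to compound 2 (beyond the scatter), with ethyl in place of 3,5-difluorophenyl on a saturated chain carbon bound to an aromatic nitrogen. That step is large, so changes to this chain can move the number a long way. Within the data shown here, no measured pair shows a chain simply being lengthened, so the scale remains rough. The expected change is a number 3.30 log units higher from compound 2 to compound 3 (beyond the scatter), upward and larger than the measured step. For compound 3 the estimated value is 4.2, with an expected range from 3.4 to 5.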

Compound 3, partition coefficient: 3.82
Compound 3: middle estimate off by 0.38 log units, on the high side; the measured number falls inside the stated range.
By their numbers in this assay, from the lowest: compound 2; then compound 1; then compound 3.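

In this assay, within the data shown here, the heptyl in place of hydrogen, on a saturated chain carbon, three bonds along the chain from an aromatic nitrogen, gives a number 2.92 log units higher from compound 2 to compound 3 (beyond the scatter); this is the first measured case here of a chain simply being lengthened, and the number moves a long way. Nonyl in place of 3,5-difluorophenyl gives a number 1.70 log units higher from compound 1 to compound 3 (beyond the scatter), so an open chain with no ring can take the number beyond that of the ring-bearing compound. Nothing measured here gives a reason for these shifts.

The compounds shown leave open whether the number climbs evenly with each added carbon, which a hexyl chain would help to test. They also leave open what an amine or a carboxylic acid at the end of the chain would do to the number.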